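The source may report more compounds than this note shows. Statements on the series, on what has been measured and on what is new or still open speak of the compounds shown alone.

In an ADME assay on Caco-2 cells (Homo sapiens) for permeability, in the apical to basolateral direction, at pH 7.4 (a lower number here means that the compound crosses the layer more slowly, a higher number that the compound crosses the layer faster), compound 1 `O=C(N[C@H]1CN(S(=O)(=O)c2ccccc2)C[C@@H]1C(=O)N[C@H]1CCCNC1)c1cc(C2CC2)n[nH]1` gives 0.39 10^-6 cm/s, and compound 2 `O=C(N[C@H]1CN(S(=O)(=O)c2ccccc2)C[C@@H]1C(=O)N[C@H]1CCCNC1)c1cc(-c2ccccc2)on1` gives 0.12 10^-6 cm/s. Compound 3 `O=C(N[C@H]1CN(S(=O)(=O)c2ccccc2)C[C@@H]1C(=O)N[C@H]1CCCNC1)c1cc(-c2ccc(Cl)cc2)on1` gives < 0.01 10^-6 cm/s, which is a limit and not a number. Compound 3 therefore stands at the limit of < 0.01 10^-6 cm/s in this assay, at which 1 of the 3 values shown sits. Compound 4 `O=C(N[C@H]1CN(S(=O)(=O)c2ccccc2)C[C@@H]1C(=O)N[C@H]1CCCNC1)c1cc(-c2ccc(Cl)cc2Cl)on1` differs from compound 3 by chloro in place of hydrogen on an aromatic carbon, which turns 4-chlorophenyl into 2,4-dichlorophenyl. The closest measured change is the same swap of chloro in place of hydrogen, a large step: an at least 12-fold lower number from compound 2 to compound 3 (1.07 log units; beyond the scatter). The modest step of a 3.3-fold lower number from compound 1 to compound 2 (0.51 log units; beyond the scatter) and the large step of an at least 39-fold lower number from compound 1 to compound 3 (1.59 log units; beyond the scatter) exchange the whole group on the carbonyl carbon, so they bear on this change less directly. A further fall is therefore expected in this assay, and the result may again be only a limit. The expected step is a step that the limit leaves unreadable from compound 3 to compound 4. Compound 4 is estimated at 0.006 10^-6 cm/s, with an expected range from 0.002 10^-6 cm/s to 0.02 10^-6 cm/s.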

Compound 4, apparent permeability: < 0.07 10^-6 cm/s
Compound 4 was reported as a limit (the forecaster's own chance of this, stated with the estimate: 85%); the middle value does not contradict the limit.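

Like the compound before it, compound 4 is reported in this assay only as a limit: the limit of < 0.07 10^-6 cm/s in this assay, at which 1 of the 4 values shown sits. On these data alone, the step between these two limits cannot be read, so the effect of adding a second chloro, ortho to a large group and meta to a chloro group, remains unknown. Set against the unsubstituted phenyl, the two chloro groups together give only an at least 1.7-fold lower number from compound 2 to compound 4 (0.23 log units; that floor lies within the scatter), a floor too low to show a real fall.

As far as these compounds go, whether the second chloro changes the number at all stays open. So does what an amine or a carboxylic acid at this place on the ring would give.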